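One Stereocentre Redrawn, Clearance in Question

This account rests on a few compounds, and the source may have more. Where it says the series, first, only, none or still open, it means among the compounds named here.

In an in vivo ADME assay on the whole organism (liver, strain Swiss) for pharmacokinetics, with Mus musculus as the target, read by LC-MS, at a dose of 2.5 mg/kg by the intravenous route (on this read-out lower numbers stand for slow clearance and higher numbers for fast clearance), compound 1 `Nc1ncnc2c1nc(Sc1cc3c(cc1Br)OCCO3)n2CCC1CCN(C=O)CC1` gives 43.1 mL/min/kg and compound 2 `C[C@H](O)C(=O)N1CCC(CCn2c(Sc3cc4c(cc3Br)OCCO4)nc3c(N)ncnc32)CC1` gives 28.5 mL/min/kg on the same scale. Compound 2 therefore stands level with compound 1 within the usual scatter. Going by the values given here, the one measured step between them is a 1.5-fold lower number from compound 1 to compound 2 (0.18 log units; within the scatter) and puts a 1-hydroxyethyl in place of hydrogen on a carbonyl carbon.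

Compound 3 `C[C@@H](O)C(=O)N1CCC(CCn2c(Sc3cc4c(cc3Br)OCCO4)nc3c(N)ncnc32)CC1` has not yet been measured. Set against compound 2 it shows the two compounds have the same atoms and bonds and differ only in configuration as drawn: 1 of 1 stereo elements differ; a stereocentre at a saturated chain carbon is drawn S in compound 2 and R in compound 3 and nothing else: a stereocentre at a saturated chain carbon is drawn S in compound 2 and R in compound 3. Among the compounds with values here, no measured pair here tests a change of configuration, so the data give no direction for this step. Within the data shown here, the only available step concerns a different change and stayed within the scatter, so the expected shift in this assay also stays within the scatter. Compound 2 at 28.5 mL/min/kg serves as the starting point. The expected size is a 1.1-fold higher number from compound 2 to compound 3 (0.02 log units; within the scatter) and neither direction is favoured. Compound 3 is estimated at 30 mL/min/kg in this measurement, with an expected range from 15 mL/min/kg to 55 mL/min/kg around that figure.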

Compound 3, clearance: 27.3 mL/min/kg
Compound 3: middle estimate off by 1.1-fold (0.04 log units), on the high side; the measured number falls inside the stated range.
By their numbers in this assay, from the lowest: compounds 3, 2 and 1 (each within the scatter of the next).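

Redrawing the stereocentre at the saturated chain carbon from S to R gives a 1.0-fold lower number from compound 2 to compound 3 (0.02 log units; within the scatter), and this is the first measured test of configuration at this position: in this assay, the two mirror-image arrangements of the 1-hydroxyethyl cannot be told apart. The second new step, which puts the 1-hydroxyethyl in place of hydrogen on a carbonyl carbon, gives a 1.6-fold lower number from compound 1 to compound 3 (0.20 log units; within the scatter), so this change stays within the scatter in the R form as well as in the S form. The comparison between the two forms is a clean one, since no other part of the structure varies: the fact that compounds 2 and 3 differ only in the configuration as drawn

The compounds shown leave open whether a different group on that carbonyl carbon, such as a plain ethyl without the hydroxyl, an amine or a longer chain, would shift clearance beyond the scatter. They also cannot tell whether configuration would matter at this carbon with any such group in place, or in any read-out other than this assay.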